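Swapping an aryl ether for a branched alkyl chain

This account rests on a few compounds, and the source may have more. Where it says the series, first, only, none or still open, it means among the compounds named here.

Measured compounds:
compound 1, `COc1ccccc1Oc1ccc2c(NCCCNCc3ccco3)ccnc2c1`, 6500 nM
compound 2, `COc1cccc(Oc2ccc3c(NCCCNCc4cc(F)ccc4OC)ccnc3c2)c1`, 7100 nM

Two compounds on the shared core have been run in an ADME assay on HepG2 cells (Homo sapiens) for cytotoxicity, read by luminescence, CellTiter-Glo and ATP content, with a stated time of 72 h; on this read-out lower numbers stand for an effect already at smaller amounts and higher numbers for an effect only at larger amounts of compound. Compound 1 gives 6500 nM, the lowest of the two numbers, and compound 2 gives 7100 nM; the gap between them lies within the scatter of this assay, so the two readings show the same behaviour. Going by the values given here, no step between two measured compounds that differ in one place is available.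

Compound 3, `CCC(CC)c1ccc2c(NCCCNCc3ccco3)ccnc2c1`, has not yet been measured. It differs from compound 1 in one place: pentan-3-yl in place of 2-methoxyphenoxy on an aromatic carbon. The change removes a ring and two hydrogen-bond acceptors and puts a short branched chain in their place.

With only the reading of compound 1 to rest on, and with compound 2 sitting within the scatter of it, no step beyond the scatter is expected for compound 3 in this assay; the step from compound 1 to compound 3 is estimated at a 1.2-fold higher number from compound 1 to compound 3 (0.09 log units; within the scatter). Compound 3 is therefore expected to give 8000 nM, within a range from 3000 nM to 22000 nM.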

Compound 3, half-maximal effective concentration: 6760 nM
Estimate against measurement, compound 3: 1.2-fold (0.07 log units) above; low and high end bracket the measured number.
By their numbers in this assay, from the lowest: compounds 1, 3 and 2 (each within the scatter of the next).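

In this assay, going by these compounds alone, putting pentan-3-yl in place of 2-methoxyphenoxy on this aromatic carbon gives a step of a 1.0-fold higher number from compound 1 to compound 3 (0.02 log units; within the scatter), the first direct comparison of two compounds that differ in one place on the shared core. It shows that, for this pair, the read-out does not separate the two groups, even though the six-membered aromatic ring and the hydrogen-bond acceptors of 2-methoxyphenoxy are absent from pentan-3-yl, so neither feature is needed at this position to give a reading of this size. No measurement in hand accounts for why the two readings stand so close together.

From the compounds shown here alone, whether a carboxylic acid, a primary amine or a longer alkyl chain on this same aromatic carbon would also stay within the scatter of compound 1 remains open. Going by these compounds, it is also open whether pentan-3-yl and 2-methoxyphenoxy would read alike with a different group at the far end of the side chain, since this single pair shares one side chain and cannot speak for others.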